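Swapping the para-bromophenyl for an ortho-methoxyphenyl

The compounds below may be only part of what the source reports. "The series", "measured", "known", "first", "only" and "open" are said of these compounds alone.

Measured so far:
compound 1, `CC(=O)c1ccc(-c2cn3ccnc3c(-c3ccc4ncn(C5CCCCC5)c4c3)n2)cc1`, 14.5%
compound 2, `Brc1ccc(-c2cn3ccnc3c(-c3ccc4ncn(C5CCCCC5)c4c3)n2)cc1`, 30.7%

In a functional assay on LOX IMVI cells (Homo sapiens) for inhibition, read by sulforhodamine B assay, with a stated time of 48 h, tested at 10 uM (on this read-out lower numbers stand for less inhibition and higher numbers for more inhibition at the one concentration tested (going by the name of the read-out)), compound 2 gives the higher of the two numbers recorded; compound 1 sits a number 16.2 percentage points higher from compound 1 to compound 2 (beyond the scatter), which means a modest rise on going from acetyl to bromo on the aromatic carbon of the pendant phenyl ring. Both numbers are low on the percentage scale, so the inhibition in this assay is low for both compounds.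

Compound 3, `COc1ccccc1-c1cn2ccnc2c(-c2ccc3ncn(C4CCCCC4)c3c2)n1`, is not yet measured. It differs from compound 2 by 2-methoxyphenyl in place of 4-bromophenyl on an aromatic carbon. Among the compounds with values here, the only measured step, from compound 1 to compound 2, concerns a different substituent at a different position of the same phenyl ring, and was modest in size. Within the data shown here, no step in the set involves a methoxy group or an ortho substituent, so the direction for compound 3 cannot be read from the data. Compound 3 is therefore expected to stay near compound 2, with a change of about a number 8.7 percentage points lower from compound 2 to compound 3 (within the scatter), which lies within the scatter. The estimate for compound 3 in this assay is 22%, with a range from 5% to 42%.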

Compound 3, a percentage reported as inhibition, at one concentration (the size of the read-out at that concentration, not a potency): 5.13%
Estimate against measurement, compound 3: 16.9 percentage points above, and the stated range covers the measured number.
By their numbers in this assay, from the lowest: compounds 3 and 1 (each within the scatter of the next); then compound 2.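

In this assay, within the data shown here, this position responds to more than the one substituent change seen before: replacing 4-bromophenyl with 2-methoxyphenyl gives a number 25.6 percentage points lower from compound 2 to compound 3 (beyond the scatter). The advantage of 4-bromophenyl is therefore not kept by this other substituted phenyl group. Set against 4-acetylphenyl, the same group gives a number 9.4 percentage points lower from compound 1 to compound 3 (within the scatter), so compound 3 cannot be told apart from compound 1 in this read-out. Nothing available here accounts for the drop.

The change swaps the substituent and moves its place on the phenyl ring in a single step, so the compounds shown cannot separate the contribution of the methoxy group from that of its location. They also leave open how this position would respond to an amine or a carboxylic acid on the phenyl ring.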